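A few compounds are considered here, and "the series" means these few. Any claim that something is new, unique, unknown or untested is made for them only; others in the source may bear on it.

Working notes on the permeability series.

Compound 1, `CC(C)(C)c1ccc(Oc2ccc3c(NCCCNCc4ccco4)ccnc3c2)cc1`, gives 317 10^-6 cm/s in an ADME assay for permeability, using PAMPA, with a stated time of 30 min, at pH 7.4; a lower number here means that the compound crosses the layer more slowly, a higher number that the compound crosses the layer faster. Compound 2, `CN(C)c1cccc(Oc2ccc3c(NCCCNCc4ccco4)ccnc3c2)c1`, gives 317 10^-6 cm/s in this assay, and compound 3, `c1ccc(Oc2ccc3c(NCCCNCc4ccco4)ccnc3c2)cc1`, gives 317 10^-6 cm/s. Compound 1 is level with compounds 2 and 3 at the digits shown; the steps of no change at the digits printed from compound 1 to compound 2 (within the scatter) and no change at the digits printed from compound 1 to compound 3 (within the scatter) are both within the scatter, as is no change at the digits printed from compound 2 to compound 3 (within the scatter). All three measured steps vary the aryl ether end of the shared core and leave the ((furan-2-yl)methyl)amino end untouched.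

Compound 4, `COc1ccc(F)cc1CNCCCNc1ccnc2cc(Oc3ccc(C(C)(C)C)cc3)ccc12`, differs from compound 1 at that other end: 5-fluoro-2-methoxyphenyl in place of furan-2-yl on a saturated chain carbon bound to an amine nitrogen. Going by the values given here, no measured step bears directly on this site, so the expectation rests only on the three steps above, none of which moved the read-out beyond the scatter. Compound 4 is therefore estimated at 317 10^-6 cm/s in this assay, in the range 150 10^-6 cm/s to 400 10^-6 cm/s, and the expected step of no change at the digits printed from compound 1 to compound 4 (within the scatter) is taken as none beyond the scatter.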

Compound 4, apparent permeability: 317 10^-6 cm/s
The estimate for compound 4 equals the measured number at the digits printed; low and high end bracket the measured number.
By their numbers in this assay, from the lowest: compounds 1, 2, 3 and 4 (each within the scatter of the next).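

Unlike the earlier steps, which all vary the aryl ether end, this one tests the site on a saturated chain carbon bound to an amine nitrogen, and this assay records no change at the digits printed from compound 1 to compound 4 (within the scatter). The read-out therefore stays within the scatter when a five-membered aromatic ring with 1 hetero atom gives way to a six-membered aromatic ring of carbon only, and 5 heavy atoms give way to 9 heavy atoms, with the counts of hydrogen-bond donors and acceptors the same on both sides. No supporting measurement bears on this result.

From the compounds shown here alone, both groups compared at this place are aromatic and carry no net charge, so it remains open whether a carboxylic acid or a tertiary amine there would leave the read-out level. Also open, going by these compounds, is whether 5-fluoro-2-methoxyphenyl behaves the same way on the cores of compound 2 and compound 3.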